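From Free Acid to Cyclopentylmethyl Ester on a Bromophenyl Core

This account rests on a few compounds, and the source may have more. Where it says the series, first, only, none or still open, it means among the compounds named here.

Compound 1 `C=C(C)[C@H]1CC=C(C)[C@@]2(O)[C@@H]1[C@H](c1ccccc1Br)O[C@@H]2C(=O)O` carries a free carboxylic acid on the shared core. In a functional assay on KB3 cells (Homo sapiens) for antiproliferative activity, read by MTT assay, with a stated time of 96 h (a higher number here means a weaker inhibitor, a lower number a stronger inhibitor), compound 1 gives > 100000 nM, which is a limit of the assay rather than a number. Compound 1 thus stands at the limit of > 100000 nM in this assay, at which 1 of the 3 values shown sits. Two esters show what numbers are reachable: compound 3 `C=C(C)[C@H]1CC=C(C)[C@@]2(O)[C@@H]1[C@H](c1cccc(Br)c1)O[C@@H]2C(=O)OCC`, an ethyl ester, gives in this assay 3000 nM, and compound 2 `C=C(C)[C@H]1CC(=O)C(C)=C2[C@@H](C(=O)OCC)O[C@@H](c3ccccc3Br)[C@@H]21`, an ethyl ester on a different core, gives 70000 nM. Compound 4 `C=C(C)[C@H]1CC=C(C)[C@@]2(O)[C@@H]1[C@H](c1ccccc1Br)O[C@@H]2C(=O)OCC1CCCC1` differs from compound 1 by cyclopentylmethyl in place of hydrogen on an oxygen next to a carbonyl group. A large step toward a lower number, well beyond the scatter, is expected, since compound 3 as an ester reaches 3000 nM. Compound 4 is therefore estimated at 5000 nM, between 1000 nM and 50000 nM, an expected step of an at least 20-fold lower number from compound 1 to compound 4 (1.30 log units; beyond the scatter).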

Compound 4, half-maximal inhibitory concentration: > 100000 nM
Compound 4 gave a limit, no number; the forecaster's own chance of this, stated with the estimate: 10%; middle value at least 20-fold (1.30 log units) from the limit.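

Going by these compounds alone, compound 1 and compound 4 each give only a limit, so no step from compound 1 to compound 4 can be read: the limit of > 100000 nM in this assay, at which 2 of the 4 values shown sit. The compounds shown leave open whether cyclopentylmethyl in place of hydrogen changes the result in this assay at all.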